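The source may hold more compounds than are shown below. What is called first, only, known or untested is meant among the compounds shown, and "the series" means these compounds.

In an ADME assay on Vero cells (Chlorocebus sabaeus) for cytotoxicity, read by WST assay, tested at 50 ug/mL (on this read-out higher numbers stand for a weaker effect at the one concentration tested and lower numbers for a stronger effect), compound 3 `COC(=O)[C@@H]1COC(/C=C/c2ccc(F)cc2)=N1` gives 91.6%, the highest of the three numbers seen so far. Compound 1 `O=C(/C=C/c1ccc(F)cc1)O/C(=N/C1CCCCC1)NC1CCCCC1` gives 82.5% in this assay, a number within the usual scatter of that of compound 3, so the two cannot be told apart. Compound 2 `COC(=O)[C@H](COC(=O)/C=C/c1ccccc1)NC(=O)/C=C/c1ccccc1` gives 16.8%, which lies far below compound 3, well beyond the scatter. Compound 4 `COC(=O)[C@@H]1COC(/C=C/c2ccc(C)cc2)=N1` has not yet been measured. It differs from compound 3 in one place: methyl in place of fluoro on an aromatic carbon. Among the measured compounds shown here, no step between measured compounds matches this change, so the expectation rests on the small size of the exchange alone. Compound 4 is expected to show a step of a number 3.6 percentage points lower from compound 3 to compound 4 (within the scatter) in this assay that stays within the scatter, in no direction beyond it. Compound 4 is therefore estimated at 88%, with a range from 70% to 100%.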

Compound 4, a percentage reported as activity, at one concentration (the size of the read-out at that concentration, not a potency): 85.1%
Compound 4: middle estimate off by 2.9 percentage points, on the high side; the range from low to high includes it.
By their numbers in this assay, from the lowest: compound 2; then compounds 1, 4 and 3 (each within the scatter of the next).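

In this assay, methyl in place of fluoro on an aromatic carbon, para to a large group, gives a number 6.5 percentage points lower from compound 3 to compound 4 (within the scatter) and so provides the first step read at this position. With this exchange, compound 3 and compound 4 cannot be told apart in this read-out. No measured finding bears on this result, so it remains a plain observation.

The compounds shown leave open whether an amine or a carboxylic acid at this place would also stay within the scatter. They also leave open what a longer chain there would do.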